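The source may hold more compounds than are shown below. What is called first, only, known or untested is meant among the compounds shown, and "the series" means these compounds.

In an ADME assay on microsomes from liver (Homo sapiens), read by LC-MS, using NADPH, with a stated time of 10 min, tested at 0.5 uM (a higher number here means that more of the compound is left, a lower number that less of the compound is left), compound 2 (`Cc1nc2cc(-c3cccc(-c4ccccc4)c3)nn2c(-c2cc(F)c3c(c2C)CCCO3)c1[C@H](OC(C)(C)C)C(=O)O`) gives 78%. Compound 3 (`Cc1nc2cc(-c3cccc(-c4ccccc4)c3)nn2c(-c2cc(F)c3c(c2C)CCCO3)c1C(OC(C)(C)C)C(=O)O`) gives 86%. Compound 1 (`Cc1ccc(-c2cc3nc(C)c(C(OC(C)(C)C)C(=O)O)c(-c4cc(F)c5c(c4C)CCCO5)n3n2)cc1`) gives 95%. The gap between compound 2 and compound 3 lies within the scatter, while the gap between compound 2 and compound 1 lies beyond it. Compound 4 (`Cc1ccccc1-c1cccc(-c2cc3nc(C)c([C@H](OC(C)(C)C)C(=O)O)c(-c4cc(F)c5c(c4C)CCCO5)n3n2)c1`) differs from compound 2 as follows: methyl in place of hydrogen on an aromatic carbon. This places methyl in place of hydrogen on an aromatic carbon, ortho to a large group. Within the data shown here, no measured step makes this exact change, but two bear on it. Swapping 4-methylphenyl for 3-phenylphenyl gave a number 9 percentage points lower from compound 1 to compound 3 (within the scatter), and the fact that one of compounds 2 and 3 is drawn with a defined configuration and the other without, at the place where they differ accompanies a number 8 percentage points higher from compound 2 to compound 3 (within the scatter). Since both stayed small, no shift beyond the scatter is expected in this assay. The expected change is a number 2 percentage points lower from compound 2 to compound 4 (within the scatter). Compound 4 is therefore estimated at 76%, with an expected range from 60% to 91%.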

Compound 4, percent of the compound remaining: 95%
For compound 4 the middle estimate is 19 percentage points below the measured one; measured number above the stated range.
By their numbers in this assay, from the lowest: compounds 2, 3, 1 and 4 (each within the scatter of the next, the first and the last beyond it).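

In this assay, the change from phenyl to 2-methylphenyl, methyl in place of hydrogen on an aromatic carbon, ortho to a large group, gave a number 17 percentage points higher from compound 2 to compound 4 (beyond the scatter). This single added methyl thus moved the number beyond the scatter, which neither earlier step had done. Nothing among the data shown accounts for this step. As far as these compounds go, whether methoxy, ethyl or chlorine in the same place would give a similar step stays open, as does whether the step would hold for compounds drawn without a configuration.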